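A few compounds are considered here, and "the series" means these few. Any claim that something is new, unique, unknown or untested is made for them only; others in the source may bear on it.

Among the measured compounds shown here, in a functional assay for inhibition, with Homo sapiens as the target (on this read-out lower numbers stand for an effect already at smaller amounts and higher numbers for an effect only at larger amounts of compound), compound 3 (`O=C1CCC(c2ccc(NC(=O)CCCl)cc2)=NN1`) gives 0.98 ug/mL and sits at the low end of the three numbers measured so far. Compound 1 (`CCCC(=O)Nc1ccc(C2=NNC(=O)CC2)cc1`) gives 1.44 ug/mL and compound 2 (`CCCCC(=O)Nc1ccc(C2=NNC(=O)CC2)cc1`) gives 2.64 ug/mL in this assay as well. Of the steps among them, a 1.5-fold lower number from compound 1 to compound 3 (0.17 log units; within the scatter) stays inside the usual scatter, as does a 1.8-fold higher number from compound 1 to compound 2 (0.26 log units; within the scatter) on lengthening the chain. Only a 2.7-fold lower number from compound 2 to compound 3 (0.43 log units; beyond the scatter) goes beyond it, and that step is modest.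

Compound 4 (`CC(C)(CCl)C(=O)Nc1ccc(C2=NNC(=O)CC2)cc1`) differs from compound 3 by 1-(chloromethyl)-1-methylethyl in place of 2-chloroethyl on a carbonyl carbon in that 1-(chloromethyl)-1-methylethyl stands in place of 2-chloroethyl on a carbonyl carbon. The chlorine stays, while the chain gains carbon. For the measured compounds named here, no measured compound carries this branched group, so the three steps bear on the change only indirectly. Going by the values given here, they show that chain changes of this kind have so far moved the number little, and that the one step beyond the scatter, a 2.7-fold lower number from compound 2 to compound 3 (0.43 log units; beyond the scatter), was small. A small move is therefore expected, perhaps slightly upward, and probably none beyond the scatter. On that reasoning, a 1.3-fold higher number from compound 3 to compound 4 (0.12 log units; within the scatter) is the expected step. Compound 4 is estimated at 1.3 ug/mL in this assay, with a range of 0.5 ug/mL to 3.5 ug/mL expected.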

Compound 4, half-maximal effective concentration: 11.4 ug/mL
The estimate for compound 4 lay 8.8-fold (0.94 log units) below the measured number, and the stated range ends below it.
By their numbers in this assay, from the lowest: compounds 3, 1 and 2 (each within the scatter of the next, the first and the last beyond it); then compound 4.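

Among the compounds shown here, at this position, the carbonyl carbon whose other neighbour is the amide-type nitrogen, this assay turns out to be far from indifferent to the group carried: the change from 2-chloroethyl to 1-(chloromethyl)-1-methylethyl gives the only large step seen so far (a 12-fold higher number from compound 3 to compound 4 (1.07 log units; beyond the scatter)). Compound 4 also stands clear of the unchlorinated chains, both the butyl of compound 2 (a 4.3-fold higher number from compound 2 to compound 4 (0.64 log units; beyond the scatter)) and the propyl of compound 1 (a 7.9-fold higher number from compound 1 to compound 4 (0.90 log units; beyond the scatter)), so the small moves among compounds 1, 2 and 3 did not extend to this group, and keeping the chlorine did not keep the number low. Nothing in the available data accounts for this rise.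

The compounds shown leave open whether the higher number goes with the two added carbons, with the way they are attached, or with the chlorine in its new setting. Compounds carrying 1,1-dimethylethyl, 1-methylethyl or 3-chloropropyl on the same carbonyl carbon would help to separate these possibilities, and the compounds shown say nothing yet about how any of these would read.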